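The compounds below may be only part of what the source reports. "The series", "measured", "known", "first", "only" and "open" are said of these compounds alone.

Of the compounds shown here, three sharing one core have been tested in a functional assay on CHO-K1 cells for agonist activity at adenosine receptor A1 (Homo sapiens), read by GTPgammaS binding; a lower number here means that less compound is needed, a higher number that more compound is needed for the effect. Compound 1 `Nc1sc(Br)c(-c2cccc(C(F)(F)F)c2)c1C(=O)c1ccccc1` reaches only the limit of the assay, > 10 uM. Compound 2 `Nc1scc(-c2cccc(C(F)(F)F)c2)c1C(=O)c1ccccc1` gives 15.8 uM in this assay. Compound 3 `COc1ccc(-c2sc(N)c(C(=O)c3ccccc3)c2-c2cccc(C(F)(F)F)c2)cc1` likewise reaches only a limit, > 10 uM. The measured steps are a step that the limit leaves unreadable from compound 1 to compound 2, a step that the two limits leave unreadable from compound 1 to compound 3 and a step that the limit leaves unreadable from compound 2 to compound 3; none of them can be read. Compound 3 therefore stands at the limit of > 10 uM in this assay, at which 2 of the 3 values shown sit, without a number of its own.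

Compound 4 `CCOC(=O)c1c(N)sc(-c2ccc(OC)cc2)c1-c1cccc(C(F)(F)F)c1` differs from compound 3 by ethoxy in place of phenyl on a carbonyl carbon. For the measured compounds named here, no measured step touches this position, and every measured step is unreadable, so neither size nor direction for this assay can be taken from them. Since compound 3 sits at the limit of > 10 uM in this assay, at which 2 of the 3 values shown sit, compound 4 is expected to stay weak as well. Compound 4 is estimated at 20 uM, within 7 uM to 60 uM. The estimated step from compound 3 to compound 4 is a step that the limit leaves unreadable from compound 3 to compound 4, with a large chance that only a limit is reported.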

Compound 4, concentration for half-maximal effect: > 10 uM
Compound 4 was reported as a limit (the forecaster's own chance of this, stated with the estimate: 70%); the middle value does not contradict the limit.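

Compound 3 and compound 4 are both reported only as limits in this assay, so the step between them cannot be read. The compounds shown leave open whether ethoxy in place of phenyl on a carbonyl carbon shifts the value at all, with most values sitting at one limit: the limit of > 10 uM in this assay, at which 3 of the 4 values shown sit.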